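Changing the group between the two ring oxygens

The source may hold more compounds than are shown below. What is called first, only, known or untested is meant among the compounds shown, and "the series" means these compounds.

Compound 1 `O=C(O)CC/C=C\CC1COC(c2ccccc2Cl)OC1c1cccnc1` in an assay for inhibition of Thromboxane-A synthase (Homo sapiens), using microsomes (a higher number here means a weaker inhibitor, a lower number a stronger inhibitor), gives 48 nM.
Compound 2 `O=C(O)CC/C=C\CC1COC(c2ccc(C(F)(F)F)cc2)OC1c1cccnc1` in this assay gives 44 nM.

Among the compounds with values here, compound 2 has the smallest of the two numbers measured so far, yet the gap to compound 1 lies within the scatter, so neither compound can be called the stronger inhibitor. Within the data shown here, the single measured step, a 1.1-fold lower number from compound 1 to compound 2 (0.04 log units; within the scatter), shows that exchanging one aromatic group for another on that saturated ring carbon left the number essentially unchanged.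

Compound 3 `CC(C)(Oc1ccccc1)C1OCC(C/C=C\CCC(=O)O)C(c2cccnc2)O1` has not yet been measured. It differs from compound 2 at the same place: a group of 10 heavy atoms (9 carbon, 1 oxygen; one six-membered aromatic ring of carbon only) in place of a group of 10 heavy atoms (7 carbon, 3 fluorine; one six-membered aromatic ring of carbon only), on a saturated ring carbon. The entering group has no common name and carries an oxygen, so it is not a simple aromatic ring on that carbon as in compound 1 and compound 2. The step from compound 1 to compound 2 bears on the question only in showing that this position tolerates a change of aromatic group; it says nothing about a group of this new kind. The expected step from compound 2 to compound 3 is therefore cautious and leans toward a somewhat higher number: a 2.3-fold higher number from compound 2 to compound 3 (0.36 log units; beyond the scatter). Compound 3 is estimated at 100 nM, with a range from 30 nM to 400 nM.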

Compound 3, half-maximal inhibitory concentration: 52 nM
Beside the measured number, compound 3's estimate is 1.9-fold (0.28 log units) above it, within the range that was stated.
By their numbers in this assay, from the lowest: compounds 2, 1 and 3 (each within the scatter of the next).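

Compound 3 shows that the saturated ring carbon between the two ring oxygen atoms accepts more than the exchange of one simple aromatic ring for another: the entering group has no common name, carries an oxygen, and has one hydrogen-bond acceptor where 4-(trifluoromethyl)phenyl has none. Both a 1.2-fold higher number from compound 2 to compound 3 (0.07 log units; within the scatter) and a 1.1-fold higher number from compound 1 to compound 3 (0.03 log units; within the scatter) stay within the scatter, so in this assay the three compounds cannot be told apart, and a group of this new kind is tolerated here as well as the two earlier aromatic groups. Nothing at hand explains why the number holds steady across these changes.

All three compounds keep a six-membered aromatic ring of carbon only within this group, which leaves open what a plain hexyl chain or an amine with no such ring would do at this carbon. On these data alone, they also share the pyridin-3-yl group and the 5-carboxypent-2-en-1-yl group, so it remains open whether the number would hold as steady if the pyridine were replaced by a phenyl ring or the carboxylic acid by an amide.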